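Amide Nitrogen Substituent: Thiazolyl to Methoxyethyl

The source may hold more compounds than are shown below. What is called first, only, known or untested is meant among the compounds shown, and "the series" means these compounds.

Compound 1 `Cc1ccc(OCC(=O)N(Cc2cccs2)c2nccs2)cc1` holds the lowest of the two numbers recorded in an assay on HEK293 cells for agonist activity at transient receptor potential cation channel subfamily M member 8 (Homo sapiens), read by fluorescence and calcium flux, with a stated time of 15 min; on this read-out lower numbers stand for an effect already at smaller amounts and higher numbers for an effect only at larger amounts of compound; in this assay compound 1 gives 2240 nM. Compound 3 `CCN(Cc1cccs1)C(=O)C(C)(C)Oc1ccc(C)cc1` gives 11000 nM in this assay, a gap to compound 1 beyond the usual scatter, and compound 2 `CCN(Cc1ccncc1)C(=O)COc1ccc(C)cc1` is reported in this assay as "not active" (no number reported), with no number at all. Compound 4 `COCCN(Cc1cccs1)C(=O)COc1ccc(C)cc1` has not yet been measured. Relative to compound 1 the change is 2-methoxyethyl in place of 1,3-thiazol-2-yl on an amide-type nitrogen. For the measured compounds named here, no step between two measured compounds that differ in one place is recorded, so the expectation rests only on what the three values show: both compounds without the 1,3-thiazol-2-yl, compound 3 at 11000 nM and compound 2 at "not active" (no number reported), lie far above compound 1. On that basis the change from compound 1 to compound 4 is expected to be a loss, a 3.6-fold higher number from compound 1 to compound 4 (0.55 log units; beyond the scatter), beyond the scatter. Compound 4 is estimated at 8000 nM, with a range from 2500 nM to 25000 nM, and a fair chance that only a limit is reported.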

Compound 4, half-maximal effective concentration: 400 nM
The estimate for compound 4 lay 20-fold (1.30 log units) above the measured number; measured number outside the range, below it.
By their numbers in this assay, from the lowest: compound 4; then compound 1; then compound 3.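

In this assay, for the compounds shown here, the step of a 5.6-fold lower number from compound 1 to compound 4 (0.75 log units; beyond the scatter) is the first single-place reading at this amide-type nitrogen, and it runs in the direction of a lower number, beyond the scatter. The 1,3-thiazol-2-yl is therefore not needed here for an effect at smaller amounts, as an open 2-methoxyethyl chain with no ring takes its place and gives the lower number of the pair. The measured compounds offer no reason for this step.

As far as these compounds go, whether the chain oxygen matters remains open, and a butyl chain, a 2-hydroxyethyl group or a 2-aminoethyl group on this nitrogen would test that. From the compounds shown here alone, this reading also rests on one pair, so it is unknown whether the same change would give a similar step with the other amide substituents or on the core of compound 3.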